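Pyrazole acids and esters: paw-edema inhibition notes

The source may report more compounds than this note shows. Statements on the series, on what has been measured and on what is new or still open speak of the compounds shown alone.

Measured so far:
compound 1 `CCOC(=O)c1nn(-c2ccc(Cl)cc2)c(-c2ccc(OC)cc2OC)c1-c1ccccc1`: 12.7%
compound 2 `COc1ccc(-c2c(C)c(C(=O)O)nn2-c2ccc(Cl)cc2)c(OC)c1`: 28.4%

The read-out throughout is a functional assay on the whole organism (strain albino) for inhibition, with Rattus norvegicus as the target, read by paw edema, with stated times of 30 min and 2 h, at a dose of 25 mg/kg by the intraperitoneal route; a lower number here means less inhibition, a higher number more inhibition at the dose given (going by the name of the read-out). Compound 2 stands highest of the two numbers; in this assay compound 2 gives 28.4%, and the nearest number, that of compound 1, is lower by a margin beyond the usual scatter. For the measured compounds named here, compound 1 and compound 2 differ in more than one place, so no single-change step between them is available; only their two values are known.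

The next compound, compound 3 `COc1ccc(-c2c(-c3ccccc3)c(C(=O)O)nn2-c2ccc(Cl)cc2)c(OC)c1`, is derived from compound 2 by one change, (phenyl in place of methyl on an aromatic carbon). Going by the values given here, no step of this exact kind has been measured. Compound 1, which also carries a phenyl on the five-membered ring, gives 12.7% in this assay, but it differs from compound 3 elsewhere, so its number is only a loose pointer.

On that basis a downward step is expected, of a size that may not clear the scatter: the expected step is a number 7.4 percentage points lower from compound 2 to compound 3 (within the scatter). For compound 3 the estimate in this assay is 21%, with a range from 8% to 34%.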

Compound 3, a percentage reported as inhibition, in the whole organism at one dose (the size of the read-out at that dose, not a potency): 42%
Compound 3: middle estimate off by 21 percentage points, on the low side, outside the stated range (above it).
By their numbers in this assay, from the lowest: compound 1; then compound 2; then compound 3.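

In this assay, the position next to the ring atom that bears a carboxy group is not limited to a methyl: phenyl in place of methyl gives a number 13.6 percentage points higher from compound 2 to compound 3 (beyond the scatter), so the larger group here goes with more inhibition at the dose given, not less. With the phenyl held constant, hydrogen in place of ethyl on the oxygen next to a carbonyl group gives a number 29.3 percentage points higher from compound 1 to compound 3 (beyond the scatter), which shows that a phenyl on this position does not by itself fix the low number of the ethyl ester and that the carboxylic acid form carries the higher reading in this pair. No measurement at hand bears on why either step runs as it does.

On these data alone, it remains open whether the gain at this position belongs to the aromatic ring or simply to a larger group, a question that a cyclohexyl or a longer chain such as propyl there would address. As far as these compounds go, it is also open whether the change from ethyl ester to carboxylic acid gives a similar step with the methyl in place of the phenyl.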